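This account rests on a few compounds, and the source may have more. Where it says the series, first, only, none or still open, it means among the compounds named here.

In a functional assay on A549 cells (Homo sapiens) for cytotoxicity, read by sulforhodamine B assay, with a stated time of 72 h (on this read-out higher numbers stand for weaker inhibition and lower numbers for stronger inhibition), compound 1 `O=c1c(CNc2ccc(S(=O)(=O)Nc3ccccn3)cc2)coc2ccccc12` gives only a limit, > 100000 nM; this is the limit of > 100000 nM in this assay, at which 1 of the 2 values shown sits. Among the measured compounds shown here, compound 2 `NS(=O)(=O)c1ccc(NC2=NC(=O)/C(=C\c3coc4ccccc4c3=O)S2)cc1` is the one compound with a measured number in this assay, and in this assay compound 2 gives 2230 nM. Compound 3 `Cc1cc(NS(=O)(=O)c2ccc(NC3=NC(=O)/C(=C\c4coc5ccccc5c4=O)S3)cc2)no1` has not yet been measured. It differs from compound 2 in a single place: 5-methyl-1,2-oxazol-3-yl in place of hydrogen on a sulfonamide nitrogen. For the measured compounds named here, no step between two measured compounds is available to show what such a change does in this assay, so the expectation for compound 3 rests on the value of compound 2 alone. The step is expected to be a 1.5-fold lower number from compound 2 to compound 3 (0.17 log units; within the scatter), within the usual scatter or only a little beyond it toward stronger inhibition. The estimate for compound 3 in this assay is therefore 1500 nM, with a range from 400 nM to 6000 nM.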

Compound 3, half-maximal inhibitory concentration: > 100000 nM
Compound 3: only a limit was reported; the forecaster's own chance of this, stated with the estimate: 5%; middle value at least 66-fold (1.82 log units) from the limit.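

The step shows that this position is far from neutral: in this assay, placing 5-methyl-1,2-oxazol-3-yl on the sulfonamide nitrogen gives an at least 44-fold higher number from compound 2 to compound 3 (1.65 log units; beyond the scatter). Until now no step had shown what a change at this nitrogen does, and this one shows that, on the shared core, the sulfonamide with its hydrogen in place keeps a measurable value while this ring substituent does not. The value of compound 3 is a limit and not a number, so the full size of the step stays unknown because the read-out ends there: the limit of > 100000 nM in this assay, at which 2 of the 3 values shown sit.

As far as these compounds go, it remains open whether a group as small as methyl or acetyl on this nitrogen would keep the value of compound 2. From the compounds shown here alone, it also remains open whether a phenyl ring here would behave like 5-methyl-1,2-oxazol-3-yl.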